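The source may report more compounds than this note shows. Statements on the series, on what has been measured and on what is new or still open speak of the compounds shown alone.

Measured so far:
compound 1, `Nc1cc(N)c2nc(-c3ccccc3)c(Oc3ccc(Cl)c(Cl)c3)nc2c1` — 39800 nM
compound 2, `Nc1cc(N)c2nc(-c3ccccc3)c(Oc3ccc(F)cc3)nc2c1` — 39800 nM
compound 3, `COc1ccc(CNc2nc3cc(N)cc(N)c3nc2-c2ccccc2)cc1OC` — 39800 nM

All three carry the same diaminophenyl-substituted core; they differ only in the group attached through the oxygen or nitrogen. In a functional assay on NCI-H23 cells (Homo sapiens) for inhibition, read by sulforhodamine B assay, with a stated time of 48 h (on this read-out lower numbers stand for stronger inhibition of growth and higher numbers for weaker inhibition of growth), compound 1 gives 39800 nM and compound 2 gives 39800 nM; the step of no change at the digits printed from compound 1 to compound 2 (within the scatter) shows that exchanging the aryl group on the oxygen did nothing the assay could resolve. Compound 3, with a benzylamine in place of the aryl ether, stands level with both: in this assay compound 3 gives 39800 nM, the same reading as compound 1 and compound 2.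

Compound 4, `Nc1cc(N)c2nc(-c3ccccc3)c(NCc3ccc(F)cc3)nc2c1`, keeps the benzylamine linkage of compound 3 and differs from it by 4-fluorophenyl in place of 3,4-dimethoxyphenyl on a saturated chain carbon bound to a nitrogen on an aromatic ring. Among the measured compounds shown here, the only measured step that bears on this, no change at the digits printed from compound 1 to compound 2 (within the scatter), was flat, and moving from an aryl ether to a benzylamine in compound 3 also left the number where it was. For the measured compounds named here, nothing so far has shifted the read-out, so no step beyond the scatter is expected for compound 4 in this assay; the expected step is no change at the digits printed from compound 3 to compound 4 (within the scatter). Compound 4 is therefore estimated at 39800 nM, with a range of 20000 nM to 80000 nM.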

Compound 4, concentration for total growth inhibition: 4570 nM
Compound 4: middle estimate off by 8.7-fold (0.94 log units), on the high side; the measured number lies below the stated range.
By their numbers in this assay, from the lowest: compound 4; then compounds 1, 2 and 3 (each within the scatter of the next).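

In this assay the group on a saturated chain carbon bound to a nitrogen on an aromatic ring proves able to move the read-out: 4-fluorophenyl in place of 3,4-dimethoxyphenyl gives an 8.7-fold lower number from compound 3 to compound 4 (0.94 log units; beyond the scatter) in a series that had been flat until now. The linking atom also matters once 4-fluorophenyl is present, with an 8.7-fold lower number from compound 2 to compound 4 (0.94 log units; beyond the scatter) for (4-fluorobenzyl)amino in place of 4-fluorophenoxy on an aromatic carbon and an 8.7-fold lower number from compound 1 to compound 4 (0.94 log units; beyond the scatter) for the same group in place of 3,4-dichlorophenoxy, so neither the 4-fluorophenyl of compound 2 nor the benzylamine linkage of compound 3 lowers the number alone, and only compound 4 combines the two. No available evidence accounts for this gain.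

The shown compounds leave open whether the gain comes from the fluorine or from the loss of the two methoxy groups, which an unsubstituted benzylamine would separate. Whether a 4-chlorobenzylamine or a longer chain such as a phenethylamine holds or extends the gain also remains unanswered, and the pattern rests on compound 4 alone.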